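The compounds below may be only part of what the source reports. "The series", "measured", "known", "first", "only" and "open" are said of these compounds alone.

Two compounds share a core that carries a pyridine-linked alkyne, differing in the group at the far end of the alkyne and in the group on the amide nitrogen. Compound 1 `CN1CCc2nc(C#Cc3cccnc3)ccc2C1=O`, which bears a methyl group on the amide nitrogen and a pyridyl at the alkyne, is reported in a functional assay on HEK293 cells for positive allosteric modulation of metabotropic glutamate receptor 5 (Homo sapiens), read by FLIPR and calcium flux (on this read-out lower numbers stand for an effect already at smaller amounts and higher numbers for an effect only at larger amounts of compound), as "not active" (no number reported), so no number is attached to it. Compound 2 `O=C1c2ccc(C#Cc3ccccc3)nc2CCN1C1CCCC1`, with a cyclopentyl on the amide nitrogen and a phenyl at the alkyne, gives in this assay a value of 5.9 nM; it is the only numeric result in this set. Compound 3 `O=C1c2ccc(C#Cc3cccc(Cl)c3)nc2CCN1C1CCCC1` differs from compound 2 by chloro in place of hydrogen on an aromatic carbon. Within the data shown here, with no other pair to guide the size of such a step, a change within the usual scatter is expected, as a 1.2-fold lower number from compound 2 to compound 3 (0.07 log units; within the scatter), neither clearly stronger nor weaker. For compound 3 the estimate in this assay is 5 nM, between 1.5 nM and 20 nM.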

Compound 3, half-maximal effective concentration: 33 nM
The estimate for compound 3 lay 6.6-fold (0.82 log units) below the measured number; the whole stated range lies below it.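

Swapping phenyl for 3-chlorophenyl gives a 5.6-fold higher number from compound 2 to compound 3 (0.75 log units; beyond the scatter) in this assay, so adding one chlorine atom at this place on the ring changes the result by more than the usual scatter. Among these compounds, until now there was no measured step to show how this position responds, and this first one shows that chloro here moves the number in the unfavourable direction, although compound 3 still has a measurable value of 33 nM. Nothing measured here explains why the number rises.

As far as these compounds go, whether a fluoro, a methoxy or an amine on this same carbon would shift the number as far, or the other way, remains open. It is also unknown whether chloro on a different carbon of the phenyl ring would have the same effect.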